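Swapping an alkyne for a chloroaryl group on the shared core

This account rests on a few compounds, and the source may have more. Where it says the series, first, only, none or still open, it means among the compounds named here.

Measured compounds:
- compound 1 `CCCC#Cc1cc([C@@H]2O[C@H](CO)[C@@H](O)[C@H]2O)n2ncnc(N)c12`: 200 nM
- compound 2 `CCCCC#Cc1cc([C@@H]2O[C@H](CO)[C@@H](O)[C@H]2O)n2ncnc(N)c12`: 2900 nM
- compound 3 `Nc1ncnn2c([C@@H]3O[C@H](CO)[C@@H](O)[C@H]3O)cc(-c3ccccc3)c12`: 82600 nM

In a functional assay on HCT-116 cells (Homo sapiens) for antiproliferative activity, with a stated time of 72 h (a higher number here means a weaker inhibitor, a lower number a stronger inhibitor), compound 1 gives 200 nM, the lowest number of the three. Its nearest neighbour is compound 2, reached by a 15-fold higher number from compound 1 to compound 2 (1.16 log units; beyond the scatter). Compound 3 lies furthest away: a 410-fold higher number from compound 1 to compound 3 (2.62 log units; beyond the scatter).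

Compound 4 `Nc1ncnn2c([C@@H]3O[C@H](CO)[C@@H](O)[C@H]3O)cc(-c3ccc(Cl)cc3)c12` has not yet been measured. It differs from compound 1 as follows: 4-chlorophenyl in place of pent-1-yn-1-yl on an aromatic carbon. Going by the values given here, the step that bears most directly on this change is the one from compound 1 to compound 3, where a phenyl replaced the same pent-1-yn-1-yl and the number rose sharply, a 410-fold higher number from compound 1 to compound 3 (2.62 log units; beyond the scatter). The step from compound 2 to compound 3, a 28-fold higher number from compound 2 to compound 3 (1.45 log units; beyond the scatter), points the same way. Among the compounds with values here, a chlorine on the phenyl has no measured precedent here, so compound 4 is expected to land close to compound 3, with the ring rather than the chlorine setting the size of the step.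

Compound 4 is therefore expected to show a large rise in this assay relative to compound 1, a 300-fold higher number from compound 1 to compound 4 (2.48 log units; beyond the scatter), and its estimated value is 60000 nM, within a range of 15000 nM to 250000 nM.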

Compound 4, half-maximal inhibitory concentration: 59300 nM
Beside the measured number, compound 4's estimate is 1.0-fold (0.01 log units) above it, and the stated range covers the measured number.
By their numbers in this assay, from the lowest: compound 1; then compound 2; then compounds 4 and 3 (each within the scatter of the next).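

In this assay, adding chloro to the phenyl group leaves the result within the scatter (a 1.4-fold lower number from compound 3 to compound 4 (0.14 log units; within the scatter)), so this chlorine does not separate compound 4 from compound 3. The large gap to the alkynes therefore remains with 4-chlorophenyl on this aromatic carbon, both against pent-1-yn-1-yl (a 300-fold higher number from compound 1 to compound 4 (2.47 log units; beyond the scatter)) and against hex-1-yn-1-yl (a 20-fold higher number from compound 2 to compound 4 (1.31 log units; beyond the scatter)), which extends the pattern seen with phenyl to a second aryl group. Nothing available accounts for this gap.

On these data alone, it remains open whether a 4-methoxyphenyl or 4-aminophenyl group would also match phenyl, or whether any aryl group could come close to the alkynes. As far as these compounds go, it is equally open whether a shorter chain such as but-1-yn-1-yl would continue the trend from hex-1-yn-1-yl to pent-1-yn-1-yl.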